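Amide variation on an indole ether scaffold against monoamine oxidase B

This account rests on a few compounds, and the source may have more. Where it says the series, first, only, none or still open, it means among the compounds named here.

Compound 1 `CCOC(=O)c1cc2cc(OCCCC3CCN(Cc4ccccc4)CC3)ccc2n1C` and compound 2 `Cn1c(C(=O)Nc2ccccc2)cc2cc(OCCCC3CCN(Cc4ccccc4)CC3)ccc21` share a core and differ only at the carbonyl carbon. In an assay on isolated protein for inhibition of Amine oxidase [flavin-containing] B (Homo sapiens), read by fluorescence, with stated times of 30 min and 1 h (on this read-out lower numbers stand for stronger inhibition and higher numbers for weaker inhibition), compound 1 gives > 100000 nM, which is a limit of the assay and not a number. In this assay compound 2 likewise gives > 100000 nM, again a limit rather than a number. The step that the two limits leave unreadable from compound 1 to compound 2 therefore cannot be sized, and compound 2 stands only at the limit, as the limit of > 100000 nM in this assay, at which 2 of the 2 values shown sit, records. Compound 3 `Cn1c(C(=O)N2CCOCC2)cc2cc(OCCCC3CCN(Cc4ccccc4)CC3)ccc21` is the next member of the series, not yet measured. It differs from compound 2 by morpholin-4-yl in place of anilino on a carbonyl carbon. Going by the values given here, the only measured step is the one from compound 1 to compound 2, and its size is unreadable, so no direction can be drawn from it. With both neighbours at the limit, compound 3 is expected to sit there as well, the step that the limit leaves unreadable from compound 2 to compound 3 being an expectation of no change beyond the scatter. Compound 3 is thus estimated at 150000 nM, within a range from 30000 nM to 1000000 nM.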

Compound 3, half-maximal inhibitory concentration: > 100000 nM
Compound 3: only a limit was reported (the forecaster's own chance of this, stated with the estimate: 85%); the middle value lies beyond the limit too.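

Compound 3 stands with compound 1 and compound 2 at the same limit of the assay, so none of the steps among these three compounds can be read: the limit of > 100000 nM in this assay, at which 3 of the 3 values shown sit. The compounds shown leave open whether any group on the carbonyl carbon gives a value inside the assay's range, and how far ethoxy, anilino and morpholin-4-yl truly differ.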